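From 3-acetylphenyl to 4-acetylphenyl on a shared core

The compounds below may be only part of what the source reports. "The series", "measured", "known", "first", "only" and "open" are said of these compounds alone.

Of the compounds shown here, three sharing one core have been measured in a functional assay (aorta) with Rattus norvegicus as the target; a higher number here means a weaker inhibitor, a lower number a stronger inhibitor. With a 3-chlorophenyl group, compound 1 `CC1(C)Oc2ccc(C#N)cc2[C@@H](/N=C(\NC#N)Nc2cccc(Cl)c2)[C@@H]1O` gives 600 nM. With a 4-(trifluoromethyl)phenyl group, compound 2 `CC1(C)Oc2ccc(C#N)cc2[C@@H](/N=C(\NC#N)Nc2ccc(C(F)(F)F)cc2)[C@@H]1O` gives 8100 nM. With a 3-acetylphenyl group, compound 3 `CC(=O)c1cccc(N/C(=N/[C@@H]2c3cc(C#N)ccc3OC(C)(C)[C@H]2O)NC#N)c1` gives 8400 nM. Compound 3 therefore stands level with compound 2, and both lie far from compound 1, which has the lowest number.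

The next structure, compound 4 `CC(=O)c1ccc(N/C(=N/[C@@H]2c3cc(C#N)ccc3OC(C)(C)[C@H]2O)NC#N)cc1`, differs from compound 3 as follows: 4-acetylphenyl in place of 3-acetylphenyl on an amine nitrogen. Among the measured compounds shown here, no measured pair tests this change directly, so the evidence is indirect. The two large steps, a 14-fold higher number from compound 1 to compound 2 (1.13 log units; beyond the scatter) and a 14-fold higher number from compound 1 to compound 3 (1.15 log units; beyond the scatter), both start from compound 1 and say little about moving the acetyl group. More relevant is the step of a 1.0-fold higher number from compound 2 to compound 3 (0.02 log units; within the scatter), which shows that the 4-substituted compound 2 and the 3-substituted compound 3 read alike. On that basis, no change beyond the scatter is expected in this assay. The estimated step is a 1.1-fold lower number from compound 3 to compound 4 (0.02 log units; within the scatter). Compound 4 is estimated at 8000 nM, with an expected range from 2000 nM to 28000 nM.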

Compound 4, half-maximal inhibitory concentration: 21000 nM
Estimate against measurement, compound 4: 2.6-fold (0.42 log units) below; the measured number falls inside the stated range.
By their numbers in this assay, from the lowest: compound 1; then compounds 2 and 3 (each within the scatter of the next); then compound 4.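

In this assay, among the compounds shown here, the place of the acetyl group on the phenyl ring proves to matter, a point the earlier compounds could not settle because none of them shared a substituent at two places (a 2.5-fold higher number from compound 3 to compound 4 (0.40 log units; beyond the scatter)). Acetyl and trifluoromethyl also separate once both are compared as 4-substituted phenyl groups (a 2.6-fold higher number from compound 2 to compound 4 (0.41 log units; beyond the scatter)), and the 4-acetylphenyl group gives the widest gap yet from the 3-chlorophenyl group (a 35-fold higher number from compound 1 to compound 4 (1.54 log units; beyond the scatter)). Nothing shown bears on the reason for these steps.

The compounds shown do not tell whether the difference between the 3-acetylphenyl and 4-acetylphenyl groups also holds for chloro or trifluoromethyl when moved in the same way. From the compounds shown here alone, how a methoxy group, an amine or a carboxylic acid on this phenyl ring would read also remains open.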